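This account rests on a few compounds, and the source may have more. Where it says the series, first, only, none or still open, it means among the compounds named here.

Two compounds of the series have numbers in a physicochemical assay for lipophilicity (a higher number here means a more lipophilic compound, a lower number a more polar compound), so far. Compound 1 `Cc1cc(Cl)cc(Cl)c1Nc1ccnc(Nc2ccc(C#N)cc2)n1` gives 1.14 in this assay. Compound 2 `Cc1cc(C#N)cc(C)c1Oc1nc(Nc2ccc(C#N)cc2)ncc1Br` gives 1.82 in this assay, the higher of the two numbers, and its gap to compound 1 lies beyond the scatter. Compound 3 `CC(=O)Nc1cnc(Nc2ccc(C#N)cc2)nc1Oc1c(C)cc(C#N)cc1C` has not yet been measured. It differs from compound 2 in one place: acetamido in place of bromo on an aromatic carbon. For the measured compounds named here, no measured pair covers this change, so the size of the step rests on expectation alone. A decrease well beyond the scatter is expected, a number 1.32 log units lower from compound 2 to compound 3 (beyond the scatter). Compound 3 is estimated at 0.5, with a range from -0.3 to 1.2.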

Compound 3, partition coefficient: -0.12
Compound 3: the middle estimate sits 0.62 log units above what was measured, and the stated range covers the measured number.
By their numbers in this assay, from the lowest: compound 3; then compound 1; then compound 2.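

Acetamido in place of bromo on this aromatic carbon, para to a (4-cyanophenyl)amino group, gives a number 1.94 log units lower from compound 2 to compound 3 (beyond the scatter) in this assay. For the compounds shown here, this is the first single-place step, and it shows that the number responds strongly to a change at this position. No measurement at hand bears on the reason for a step of this size.

Only one replacement has been measured at this position. The data do not tell the loss of bromo apart from the gain of acetamido. An amine or a methyl group at this position could separate the two.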